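Methylcyclopropyl Carbamate Ester on a Shared Core

This account rests on a few compounds, and the source may have more. Where it says the series, first, only, none or still open, it means among the compounds named here.

Compound 3 `CC(C)OC(=O)N1CCC(O[C@H]2CC[C@H](Oc3cnc(S(C)(=O)=O)cn3)CC2)CC1` is one of three compounds built on the same core, differing in the group on the oxygen next to a carbonyl group or in the aromatic ring on an oxygen on a saturated carbon. In a functional assay on isolated protein for agonist activity at Glucose-dependent insulinotropic receptor (Rattus norvegicus), read by HTRF and cAMP accumulation (a higher number here means that more compound is needed for the effect, a lower number that less compound is needed), compound 3 gives 119 nM. Compound 1 `CC(C)OC(=O)N1CCC(O[C@H]2CC[C@H](Oc3ccc(S(C)(=O)=O)nc3)CC2)CC1` gives 201 nM in this assay, and compound 2 `CC(C)(C)OC(=O)N1CCC(O[C@H]2CC[C@H](Oc3cnc(S(C)(=O)=O)cn3)CC2)CC1` gives 64 nM. Compound 3 therefore holds the second highest of the three numbers, yet both of its neighbours lie within the scatter: a 1.7-fold lower number from compound 1 to compound 3 (0.23 log units; within the scatter) and a 1.9-fold higher number from compound 2 to compound 3 (0.27 log units; within the scatter).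

Compound 4 `CC1(OC(=O)N2CCC(O[C@H]3CC[C@H](Oc4cnc(S(C)(=O)=O)cn4)CC3)CC2)CC1` differs from compound 3 by 1-methylcyclopropyl in place of isopropyl on an oxygen next to a carbonyl group. The step bearing most directly on this change is the one that also reworks the ester group on that oxygen, from compound 2 to compound 3, and it remained within the scatter. Among the compounds with values here, the step from compound 1 to compound 3 touches a different part of the molecule and shows only that the ring change moved the number little. On this basis no step beyond the scatter is expected in this assay, and compound 4 is estimated to give 95 nM, between 40 nM and 220 nM, an expected step of a 1.3-fold lower number from compound 3 to compound 4 (0.10 log units; within the scatter).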

Compound 4, half-maximal effective concentration: 138 nM
For compound 4 the middle estimate is 1.5-fold (0.16 log units) below the measured one; the range from low to high includes it.
By their numbers in this assay, from the lowest: compounds 2, 3, 4 and 1 (each within the scatter of the next, the first and the last beyond it).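

On an oxygen next to a carbonyl group, 1-methylcyclopropyl brings in a three-membered ring and one more carbon than isopropyl, yet in this assay the two groups cannot be told apart (a 1.2-fold higher number from compound 3 to compound 4 (0.06 log units; within the scatter)). Set against tert-butyl at the same place, 1-methylcyclopropyl gives the first step on this oxygen to pass the scatter, though only modestly (a 2.2-fold higher number from compound 2 to compound 4 (0.33 log units; beyond the scatter)), while the step between tert-butyl and isopropyl stays within it (a 1.9-fold higher number from compound 2 to compound 3 (0.27 log units; within the scatter)). No measurement offered here accounts for these numbers.

Going by these compounds, it remains open whether an amine, a carboxylic acid or a longer chain in this place would keep the number in the same range. On these data alone, it is also open whether 1-methylcyclopropyl would behave the same way on the core of compound 1.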